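This account rests on a few compounds, and the source may have more. Where it says the series, first, only, none or still open, it means among the compounds named here.

In a functional assay on the whole organism (stomach) for inhibition, with Rattus norvegicus as the target, at a dose of 100 mg/kg by the intraduodenal route (on this read-out higher numbers stand for more inhibition at the one dose given (going by the name of the read-out) and lower numbers for less inhibition), compound 2 `N=C(S)CCCCn1nc(-c2ccccc2)ccc1=O` gives 33.8%, the lowest of the two numbers shown, while compound 1 `N=C(S)CCCn1nc(-c2ccccc2)ccc1=O` gives 75.6%. The step of a number 41.8 percentage points lower from compound 1 to compound 2 (beyond the scatter) came with a longer chain between the core and the thioamide end. Compound 3 `CN(C)C(=S)CCCCCn1nc(-c2ccccc2)ccc1=O` is not yet measured; compared with compound 2 it carries a group of 6 heavy atoms (4 carbon, 1 nitrogen, 1 sulfur; no ring) in place of a group of 3 heavy atoms (1 carbon, 1 nitrogen, 1 sulfur; no ring), on a saturated chain carbon, four bonds along the chain from an aromatic nitrogen. Within the data shown here, only one measured step bears on this, and it bears on it in part: from compound 1 to compound 2 the chain grew by one carbon and this assay fell beyond the scatter, and compound 3 again moves the end group one bond further along the chain while also losing its hydrogen-bond donors, for which no comparison exists. A further fall, or no step beyond the scatter, is therefore expected, so that compound 3 is estimated at 22%, between 5% and 45%, a step of a number 11.8 percentage points lower from compound 2 to compound 3 (beyond the scatter).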

Compound 3, a percentage reported as inhibition, in the whole organism at one dose (the size of the read-out at that dose, not a potency): 58.2%
For compound 3 the middle estimate is 36.2 percentage points below the measured one, outside the stated range (above it).
By their numbers in this assay, from the lowest: compound 2; then compound 3; then compound 1.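

In this assay the chain end shows no steady loss as the chain grows: the result is a number 24.4 percentage points higher from compound 2 to compound 3 (beyond the scatter) and so the fall seen earlier does not simply continue. Here the chain lengthens while the end group changes from one with 2 hydrogen-bond donors to one with 0, so a longer chain is not poor in itself when it carries this new end group. The gain is only partial, as the result is also a number 17.4 percentage points lower from compound 1 to compound 3 (beyond the scatter) and the data given offer no explanation for either step.

Still open, going by these compounds, is how much of the rise belongs to the chain and how much to the end group, a question that the end group of compound 3 on the chain of compound 1 would help to settle. Also open, on these data alone, is how a carboxylic acid or an amine at the chain end would read in this assay on the shared core.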